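From acetyl to propanoyl: one added methyl

The source may report more compounds than this note shows. Statements on the series, on what has been measured and on what is new or still open speak of the compounds shown alone.

Measured so far in a functional assay on ileum (Cavia porcellus) for antagonist activity; a lower number here means a stronger inhibitor, a higher number a weaker inhibitor:
- compound 1 `CCCc1c(OCCCOc2ccc3c(O)c([N+](=O)[O-])c(=O)oc3c2)ccc(C(C)=O)c1O` gives 100 nM 
- compound 2 `CCCc1cc(C(C)=O)ccc1OCC(O)COc1ccc2c(O)c([N+](=O)[O-])c(=O)oc2c1` gives 700 nM 
- compound 3 `CCCc1c(OCC(O)COc2ccc3c(O)c([N+](=O)[O-])c(=O)oc3c2)ccc(C(C)=O)c1O` gives 80 nM 

Compound 3 sits level with compound 1, since the two numbers lie within the scatter of each other. Compound 2 stands apart, with a clearly higher number and so weaker inhibition.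

The next molecule, compound 4 `CCCc1c(OCC(O)COc2ccc3c(O)c([N+](=O)[O-])c(=O)oc3c2)ccc(C(=O)CC)c1O`, differs from compound 3 by one small edit (methyl in place of hydrogen on a saturated chain carbon bound to a carbonyl carbon). A methyl takes the place of a hydrogen on a saturated chain carbon bound to a carbonyl carbon, which turns acetyl into propanoyl.

Among the compounds with values here, no measured step touches this group, so the evidence is indirect. Adding a hydroxy on a saturated chain carbon gave a 1.3-fold lower number from compound 1 to compound 3 (0.10 log units; within the scatter) in this assay, and adding a hydroxy on an aromatic carbon gave an 8.8-fold lower number from compound 2 to compound 3 (0.94 log units; beyond the scatter) as a modest change. Neither says how the acetyl end responds to a methyl, so the expectation is no shift beyond the scatter, in either direction. The expected step is a 1.1-fold higher number from compound 3 to compound 4 (0.05 log units; within the scatter) and carries real uncertainty. For compound 4 the estimated value is 90 nM, with an expected range from 35 nM to 230 nM at its ends.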

Compound 4, half-maximal inhibitory concentration: 150 nM
Estimate against measurement, compound 4: 1.7-fold (0.22 log units) below; the range from low to high includes it.
By their numbers in this assay, from the lowest: compounds 3, 1 and 4 (each within the scatter of the next); then compound 2.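

The acetyl end had not been touched by any earlier step, and compound 4 gives the first reading there: in this assay, turning acetyl into propanoyl gives a 1.9-fold higher number from compound 3 to compound 4 (0.27 log units; within the scatter). One added methyl on this saturated chain carbon bound to a carbonyl carbon therefore makes no difference that can be told apart from the ordinary spread of repeated measurements, so compound 3 and compound 4 count as level in this test, and this end of the molecule can carry that one extra carbon without a clear loss of inhibition. Nothing available here offers an independent measurement that would explain this result or give it a physical basis.

What the compounds shown leave open is how far this can be taken, since a single methyl says little about a longer chain such as butanoyl, a cyclopropyl ring, or an amine placed on the same carbon. From the compounds shown here alone, it also remains open whether propanoyl in place of acetyl would read the same way on the backbone of compound 1 or of compound 2.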